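The compounds below may be only part of what the source reports. "The series", "measured", "known", "first", "only" and "open" are said of these compounds alone.

Working notes on the shared core in a functional assay on U2OS cells (Homo sapiens) for cytotoxicity, read by MTT assay, with a stated time of 48 h; on this read-out lower numbers stand for stronger inhibition and higher numbers for weaker inhibition. Compound 1 `Fc1cccc(-c2nc(Nc3ccccc3)c3cc(F)ccc3n2)c1` gives 47600 nM in this assay. Compound 2 `Fc1cccc(-c2nc(Nc3ccc(Br)cc3)c3cc(F)ccc3n2)c1` carries bromo in place of hydrogen on an aromatic carbon, and the measured step of an at least 1.0-fold higher number from compound 1 to compound 2 (0.02 log units; that floor lies within the scatter) lies within the scatter. Compound 2 itself is known only as a limit of the assay, > 50000 nM, so its standing is a range rather than a number; the relevant line is the limit of > 50000 nM in this assay, at which 1 of the 2 values shown sits. Compound 3 `Nc1ccccc1Nc1nc(-c2cccc(F)c2)nc2ccc(F)cc12` differs from compound 2 by 2-aminophenyl in place of 4-bromophenyl on a nitrogen on an aromatic ring, read one bond further out as (4-bromophenyl)amino to (2-aminophenyl)amino. Within the data shown here, the only measured step changes the same ring at a different position and with a different group, and it was flat; no measured step covers an amino group on this ring. With both known values sitting at or close to the limit, the expected step for compound 3 is a number no higher from compound 2 to compound 3 (the limit leaves the size open), that is no movement beyond the scatter. Compound 3 is therefore estimated at 50000 nM, within a range of 18000 nM to 150000 nM, and a limit rather than a number is the likelier outcome.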

Compound 3, half-maximal inhibitory concentration: 37900 nM
Compound 3: the middle estimate sits 1.3-fold (0.12 log units) above what was measured; low and high end bracket the measured number.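

The change from 4-bromophenyl to 2-aminophenyl on the nitrogen gives an at least 1.3-fold lower number from compound 2 to compound 3 (0.12 log units; that floor lies within the scatter), and it replaces a limit with a measured number at this position. Among these compounds, the addition of an amino group is the first measured amino change on this ring, and in this assay it gives a 1.3-fold lower number from compound 1 to compound 3 (0.10 log units; within the scatter), so this change leaves the read-out within the scatter of the unsubstituted phenyl compound. Compound 2 remains a limit of the assay, so the full size of any step that involves it stays unknown: the limit of > 50000 nM in this assay, at which 1 of the 3 values shown sits.

On these data alone, whether a carboxylic acid or a methoxy group on this ring would move the number beyond the scatter remains open, as does whether an amino group would read the same at another place on the ring. Also open is whether any change elsewhere on the shared core would give a step beyond the scatter, since none of the steps shown here does so.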